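From a carboxylic acid chain to an amino chain

A few compounds are considered here, and "the series" means these few. Any claim that something is new, unique, unknown or untested is made for them only; others in the source may bear on it.

For the measured compounds named here, compound 2 `O=C(O)CCCn1nc(-c2cccnc2)c2ccccc2c1=O` gives the higher of the two numbers measured so far: in an assay on isolated protein (Oryctolagus cuniculus) with Thromboxane-A synthase (Homo sapiens) as the target, tested at 1 uM (a higher number here means more inhibition at the concentration tested (going by the name of the read-out), a lower number less inhibition), compound 2 shows 73%. Compound 1 `O=C(c1cccs1)n1nc(-c2cccnc2)c2ccccc2c1=O` shows 37%. Going by the values given here, the one measured step, a number 36 percentage points higher from compound 1 to compound 2 (beyond the scatter), exchanges the whole group on the aromatic nitrogen. Compound 3 `NCCn1nc(-c2cccnc2)c2ccccc2c1=O` has not been measured; it differs from compound 2 by amino in place of carboxymethyl on a saturated chain carbon, two bonds along the chain from an aromatic nitrogen. Among the compounds with values here, no measured step changes the end of the chain in this way, so the earlier step offers only weak guidance. A modest decrease, a number 18 percentage points lower from compound 2 to compound 3 (beyond the scatter), is expected. For compound 3 an inhibition of 55% is estimated, with a range from 25% to 80%.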

Compound 3, a percentage reported as inhibition, at one concentration (the size of the read-out at that concentration, not a potency): 29%
Beside the measured number, compound 3's estimate is 26 percentage points above it, and the stated range covers the measured number.
By their numbers in this assay, from the lowest: compounds 3 and 1 (each within the scatter of the next); then compound 2.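

In this assay this change at the end of the chain gives a number 44 percentage points lower from compound 2 to compound 3 (beyond the scatter) and so costs much of the inhibition. The second step, a number 8 percentage points lower from compound 1 to compound 3 (within the scatter), leaves 2-aminoethyl level with (thiophen-2-yl)carbonyl, so the high number of compound 2 goes with 3-carboxypropyl and not with just any chain on the aromatic nitrogen. No supporting data explain this loss.

The change shortens the chain and replaces the carboxylic acid with an amine at once, so the two effects remain tangled. A 3-aminopropyl chain, with the longer length but an amine end, would help separate them.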